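This account rests on a few compounds, and the source may have more. Where it says the series, first, only, none or still open, it means among the compounds named here.

Compounds measured so far:
compound 1, `Cc1cc(Cl)c2[nH]cc(-c3ccc4ccccc4n3)c2c1`: 0.3 h
compound 2, `Fc1cc(Cl)c2[nH]cc(-c3ccc4ccccc4n3)c2c1`: 0.383 h
compound 3, `Clc1cc(Cl)c2[nH]cc(-c3ccc4ccccc4n3)c2c1`: 2.57 h

In an ADME assay on microsomes from liver (Homo sapiens) for metabolic stability, using NADPH, with a stated time of 40 min, tested at 2 uM (a higher number here means that the compound lasts longer, a lower number that the compound disappears faster), compound 2 gives 0.383 h. Among the three numbers it stands second highest: from compound 1 the step is a 1.3-fold higher number from compound 1 to compound 2 (0.11 log units; within the scatter), and from compound 2 to compound 3 the step is a 6.7-fold higher number from compound 2 to compound 3 (0.83 log units; beyond the scatter), so compound 2 sits close to compound 1 and well apart from compound 3.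

Compound 4, `Fc1cc(F)c2[nH]cc(-c3ccc4ccccc4n3)c2c1`, has not yet been measured in this assay. It differs from compound 2 in one place: fluoro in place of chloro on an aromatic carbon. Among the measured compounds shown here, two measured steps bear on this. The step of a 6.7-fold higher number from compound 2 to compound 3 (0.83 log units; beyond the scatter) shows that putting chloro in the place of fluoro raised the number well beyond the scatter; the reverse exchange, fluoro in place of chloro, is what compound 4 carries, though at a different aromatic carbon. The step of a 1.3-fold higher number from compound 1 to compound 2 (0.11 log units; within the scatter) shows that fluoro in place of methyl stayed within the scatter. Taken together, a lower number is expected for compound 4, of a modest size, with a 1.9-fold lower number from compound 2 to compound 4 (0.28 log units; within the scatter) as the expected step. Compound 4 is therefore estimated at 0.2 h in this assay, with a range from 0.08 h to 0.5 h.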

Compound 4, half-life: 0.45 h
Compound 4: middle estimate off by 2.3-fold (0.35 log units), on the low side; the range from low to high includes it.
By their numbers in this assay, from the lowest: compounds 1, 2 and 4 (each within the scatter of the next); then compound 3.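

In this assay this is the first change shown at the aromatic carbon ortho to a fused ring, which carries chloro in compounds 1, 2 and 3. Here, fluoro in place of chloro gives a 1.2-fold higher number from compound 2 to compound 4 (0.07 log units; within the scatter), so the two halogens cannot be told apart at this carbon in this pair, whereas the exchange at the other halogen-bearing carbon gives a 6.7-fold higher number from compound 2 to compound 3 (0.83 log units; beyond the scatter) and lies beyond the scatter. The data therefore show that exchanging these two halogens does not have the same outcome at both carbons, and nothing shown accounts for that difference.

Going by these compounds, what remains open is whether a methoxy group, a nitrile or an amine at this carbon would stay within the scatter of compound 2. On these data alone, it is also open whether the same fluoro for chloro exchange here would stay within the scatter with chloro or methyl at the other carbon.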